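Replacing the Ethoxy Group of Compound 1 with Hydrogen

A few compounds are considered here, and "the series" means these few. Any claim that something is new, unique, unknown or untested is made for them only; others in the source may bear on it.

In a functional assay on HCT-116 cells (Homo sapiens) for cytotoxicity, read by scintillation counting and thymidine incorporation, with a stated time of 72 h (a higher number here means a weaker inhibitor, a lower number a stronger inhibitor), compound 1 `CCOc1cc(C(=CC#N)c2cc(OC)cc(OC)c2)ccc1OC` gives 34 nM. Compound 3 `CCOc1cc(C(=CC#N)c2ccc(OC)c(N)c2)ccc1OC` gives 19 nM, within the scatter of compound 1, while compound 2 `CCOc1cc(C(=CC#N)c2cccc(OC)c2)ccc1OC` gives a far higher 450 nM. Compound 4 `COc1ccc(C(=CC#N)c2cc(OC)cc(OC)c2)cc1` has not yet been measured. Its difference from compound 1 is hydrogen in place of ethoxy on an aromatic carbon, ortho to a methoxy group and meta to a large group.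

Within the data shown here, only one measured step bears on this change, and it is large: a 13-fold higher number from compound 1 to compound 2 (1.12 log units; beyond the scatter), with hydrogen in place of methoxy on an aromatic carbon. That step removes a different group at a different place, so it is only a loose guide, though it points towards a higher number and a weaker inhibitor. A similarly large step is therefore expected, estimated as an 8.8-fold higher number from compound 1 to compound 4 (0.95 log units; beyond the scatter). The estimated value for compound 4 is 300 nM, with an expected range of 70 nM to 1500 nM.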

Compound 4, half-maximal inhibitory concentration: 1.2 nM
The estimate for compound 4 lay 250-fold (2.40 log units) above the measured number, and the stated range ends above it.
By their numbers in this assay, from the lowest: compound 4; then compounds 3 and 1 (each within the scatter of the next); then compound 2.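

In this assay the ethoxy group on the core of compound 1 proves dispensable, since hydrogen in its place gives a 28-fold lower number from compound 1 to compound 4 (1.45 log units; beyond the scatter) and this position, ortho to a methoxy group and meta to a large group, is better left with hydrogen in this pair. That direction is the opposite of a 13-fold higher number from compound 1 to compound 2 (1.12 log units; beyond the scatter), where hydrogen replaces methoxy at a different place, so removing a group from compound 1 does not have one direction across these two places. Nothing measured here gives a reason for the size or direction of this step.

From the compounds shown here alone, it remains open whether a hydroxyl group, an amine or a propoxy chain at this position would give a number closer to that of compound 4 or to that of compound 1. Going by these compounds, it is also open whether hydrogen in place of ethoxy would give a step of similar size in compound 2 or compound 3, whose other ring carries different groups.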